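The source may report more compounds than this note shows. Statements on the series, on what has been measured and on what is new or still open speak of the compounds shown alone.

In a functional assay on muscle tissue for agonist activity at histamine H2 receptor (Cavia porcellus) (on this read-out higher numbers stand for higher potency (the scale is a negative logarithm) and lower numbers for lower potency), compound 2 `N=C(NCCCc1c[nH]cn1)NCCC(c1ccc(C(F)(F)F)cc1)c1ccccn1` gives 7.23, the higher of the two numbers measured, while compound 1 `N=C(NCCCc1c[nH]cn1)NCCC(c1ccc(Br)cc1)c1ccccn1` gives 6.97. The step of a number 0.26 log units higher from compound 1 to compound 2 (within the scatter) is within the scatter, so the two compounds cannot be ranked. Compound 3 `N=C(NCCCc1c[nH]cn1)NCCC(c1cccc(F)c1)c1ccccn1` differs from compound 2 by 3-fluorophenyl in place of 4-(trifluoromethyl)phenyl on a saturated chain carbon bound to an aromatic carbon and a saturated chain carbon. Among the compounds with values here, the only measured step bears on it loosely, since it reshaped the same group and stayed within the scatter, so no shift beyond the scatter is expected. The expected step is a number 0.23 log units lower from compound 2 to compound 3 (within the scatter). Compound 3 is therefore estimated at 7, with a range from 6.4 to 7.6.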

Compound 3, negative logarithm of the half-maximal effective concentration: 7.79
Compound 3: the middle estimate sits 0.79 log units below what was measured; measured number outside the range, above it.
By their numbers in this assay, from the lowest: compounds 1 and 2 (each within the scatter of the next); then compound 3.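

In this assay, the group on the saturated chain carbon bound to an aromatic carbon and a saturated chain carbon can shift potency beyond the scatter, which the earlier swap of bromo for trifluoromethyl did not show. 3-Fluorophenyl gives a number 0.56 log units higher from compound 2 to compound 3 (beyond the scatter), and in place of 4-bromophenyl it gives a number 0.82 log units higher from compound 1 to compound 3 (beyond the scatter). No evidence at hand explains this gain. Each step changes both the substituent and its ring position, so the two effects stay tangled. As far as these compounds go, how 4-fluorophenyl or 3-bromophenyl would compare remains open.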